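The source may hold more compounds than are shown below. What is called first, only, known or untested is meant among the compounds shown, and "the series" means these compounds.

Of the compounds shown here, three built on the shared core have been measured so far. Compound 1 `Cn1ncc2c(-c3ccccc3)cc(NNC(=O)Nc3cc(Cl)nc(Cl)c3)nc21` gives 1020 nM in an assay on isolated protein for binding affinity to sphingosine 1-phosphate receptor 2 (Homo sapiens), read by surface plasmon resonance (a higher number here means weaker binding, a lower number tighter binding), compound 2 `Cc1nn(C)c2nc(NNC(=O)Nc3cc(Cl)nc(Cl)c3)cc(-c3ccc(F)cc3)c12` gives 980 nM, and compound 3 `Cc1nn(C)c2nc(NNC(=O)Nc3cc(Cl)nc(Cl)c3)cc(-c3ccco3)c12` gives 6520 nM, the highest of the three numbers. Within the data shown here, the only step between two measured compounds that differ in one place runs a 6.7-fold higher number from compound 2 to compound 3 (0.82 log units; beyond the scatter). Compound 4 `CCCc1cc(NNC(=O)Nc2cc(Cl)nc(Cl)c2)nc2c1c(C)nn2C` has not yet been measured; it differs from compound 3 in one place: propyl in place of furan-2-yl on an aromatic carbon. Among the measured compounds shown here, no measured step replaces a five-membered aromatic ring with propyl, so the only guidance comes from the one measured step, which shows that a change on this aromatic carbon can move the number by a modest amount in this assay. Without a direct precedent, the step from compound 3 to compound 4 is expected to be a 2.2-fold lower number from compound 3 to compound 4 (0.34 log units; beyond the scatter), with wide uncertainty in either direction. Compound 4 is therefore estimated at 3000 nM in this assay, within a range from 700 nM to 13000 nM.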

Compound 4, dissociation constant: 2360 nM
Compound 4: middle estimate off by 1.3-fold (0.10 log units), on the high side; the measured number falls inside the stated range.
By their numbers in this assay, from the lowest: compounds 2 and 1 (each within the scatter of the next); then compound 4; then compound 3.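

In this assay, an aromatic ring is not needed on this aromatic carbon for the number to fall: propyl, which has no ring, in place of furan-2-yl gives a 2.8-fold lower number from compound 3 to compound 4 (0.44 log units; beyond the scatter). Propyl does not match 4-fluorophenyl, however, as replacing that group gives a 2.4-fold higher number from compound 2 to compound 4 (0.38 log units; beyond the scatter), so among these three groups binding is tightest with 4-fluorophenyl, intermediate with propyl and weakest with furan-2-yl. Nothing available explains this order, so the reason for it remains unknown.

Going by these compounds, it remains open whether a longer chain such as butyl or pentyl would bind more tightly or more weakly than propyl. Also open, on these data alone, is how a saturated ring such as cyclohexyl would compare with propyl and with 4-fluorophenyl, which could help separate the effect of a ring from that of size.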